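Restoring a carbon-linked acid on the shared core

A few compounds are considered here, and "the series" means these few. Any claim that something is new, unique, unknown or untested is made for them only; others in the source may bear on it.

Compound 1 `O=C(O)CCCc1ccc(NCc2cccc(Oc3ccccc3)c2)cc1` and compound 2 `CC(C)(Oc1ccc(NCc2cccc(Oc3ccccc3)c2)cc1)C(=O)O` share one core and differ in the acid-bearing group. In a functional assay on CHO cells for agonist activity at Free fatty acid receptor 1 (Homo sapiens), read by a luciferase reporter (a higher number here means a larger maximal response, a lower number a smaller maximal response), compound 1 gives 59%, whereas compound 2 gives 14%, the lowest of the two numbers. Among the compounds with values here, the only step available, a number 45 percentage points lower from compound 1 to compound 2 (beyond the scatter), shows how strongly this part of the molecule matters. Compound 3 `CC(Cc1ccc(NCc2cccc(Oc3ccccc3)c2)cc1)C(=O)O` changes the same place: 2-carboxypropyl in place of 1-carboxy-1-methylethoxy on an aromatic carbon. Because the carbon-linked acid of compound 1 gave 59%, a rise is expected, though the shorter branched chain makes a full return uncertain. Compound 3 is estimated at 45%, between 25% and 65%, an expected step of a number 31 percentage points higher from compound 2 to compound 3 (beyond the scatter).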

Compound 3, largest response reached (reported as percent of maximum), in percent of the reference or control that the assay uses: 70%
Compound 3: middle estimate off by 25 percentage points, on the low side, and the stated range ends below it.
By their numbers in this assay, from the lowest: compound 2; then compound 1; then compound 3.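

In this assay, the change to 2-carboxypropyl gives a number 56 percentage points higher from compound 2 to compound 3 (beyond the scatter) and shows that the low response of compound 2 comes from the group at this position, not from the shared core. Set against the unbranched chain, the branched chain gives a number 11 percentage points higher from compound 1 to compound 3 (beyond the scatter) and so shows that an unbranched chain is not required here for a large response. Nothing measured here explains either step.

Still open, going by these compounds, is whether a longer chain carrying the carboxylic acid would raise the response further. Also open, on these data alone, is whether an amide could take the place of that acid.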